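Working notes: replacing the naphthyl group of compound 2

The compounds below may be only part of what the source reports. "The series", "measured", "known", "first", "only" and "open" are said of these compounds alone.

Measured compounds:
compound 1 `C[C@H](NC(=O)c1c(Cc2cccc(Cl)c2)sc2c1CCOC2)c1ccc(C(=O)O)cc1`: 3.2 nM
compound 2 `COc1ccc2cc(C#Cc3sc4c(c3C(=O)N[C@@H](C)c3ccc(C(=O)O)cc3)CCOC4)ccc2c1`: 27.2 nM
compound 3 `C[C@H](NC(=O)c1c(CCc2ccc(F)cc2)sc2c1CC(C)(C)OC2)c1ccc(C(=O)O)cc1`: 36.2 nM

All three numbers come from a functional assay on CHO/Galpha16 cells for antagonist activity at prostaglandin E2 receptor EP4 subtype (Homo sapiens), read by calcium flux, with a stated time of 15 min; on this read-out lower numbers stand for stronger inhibition and higher numbers for weaker inhibition. Compound 2 stands at the second highest of the three. Compound 3 lies within the scatter of compound 2, so the two cannot be separated on these data, whereas compound 1 gives a lower number by a margin beyond the scatter.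

Compound 4 `C[C@H](NC(=O)c1c(C#Cc2ccc(=O)[nH]c2)sc2c1CCOC2)c1ccc(C(=O)O)cc1` differs from compound 2 in one place: a group of 7 heavy atoms (5 carbon, 1 nitrogen, 1 oxygen; one six-membered aromatic ring with 1 hetero atom) in place of a group of 12 heavy atoms (11 carbon, 1 oxygen; 2 six-membered aromatic rings of carbon only), on a triple-bonded carbon. Among the compounds with values here, no pair of measured compounds isolates this change, and the 6-methoxynaphthalen-2-yl group of compound 2 has no counterpart elsewhere in the measured set, so there is no direct guide to its size. Within the data shown here, with only three numbers available, the expected step is a 1.5-fold higher number from compound 2 to compound 4 (0.17 log units; within the scatter), toward a weaker reading or none beyond the scatter. Compound 4 is accordingly estimated at 40 nM, with a range from 10 nM to 160 nM.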

Compound 4, half-maximal inhibitory concentration: 642 nM
Estimate against measurement, compound 4: 16-fold (1.21 log units) below, outside the stated range (above it).
By their numbers in this assay, from the lowest: compound 1; then compounds 2 and 3 (each within the scatter of the next); then compound 4.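

In this assay, the group on the triple-bonded carbon proves sensitive to this exchange: 6-methoxynaphthalen-2-yl giving way to the group with one six-membered aromatic ring with 1 hetero atom and 1 hydrogen-bond donor gives a 24-fold higher number from compound 2 to compound 4 (1.37 log units; beyond the scatter). On the aromatic carbon, the exchange of one group for another gives a 200-fold higher number from compound 1 to compound 4 (2.30 log units; beyond the scatter), so neither of these two reference points comes close to the number of compound 4. Nothing measured here accounts for the size of these steps.

The compounds shown do not separate the loss of the second aromatic ring and the methoxy group from the arrival of the ring nitrogen and its carbonyl. A plain phenyl or a 6-methoxypyridin-3-yl group on the triple-bonded carbon would bear on that question.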